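A few compounds are considered here, and "the series" means these few. Any claim that something is new, unique, unknown or untested is made for them only; others in the source may bear on it.

Measured in an assay on isolated protein for binding affinity to 5-hydroxytryptamine receptor 5A (Homo sapiens); on this read-out lower numbers stand for stronger inhibition and higher numbers for weaker inhibition:
compound 1 `CCCOCCNC1=Nc2ccccc2C(C)N1` — 241 nM
compound 2 `CC1NC(NCC2COc3ccccc3O2)=Nc2ccccc21` — 37 nM
compound 3 `CC1NC(NC[C@H]2CCCO2)=Nc2ccccc21` — 163 nM

Compound 1 gives the highest number of the three in this assay. Its nearest neighbour is compound 3: a 1.5-fold lower number from compound 1 to compound 3 (0.17 log units; within the scatter). Compound 2 stands furthest away, with a number well below that of compound 1; the two are not joined by a single-point change, so only the two values themselves can be compared.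

Compound 4 `CC1NC(NCCC2CCCCC2)=Nc2ccccc21` differs from compound 1 in one place: cyclohexyl in place of propoxy on a saturated chain carbon, two bonds along the chain from an amine nitrogen. For the measured compounds named here, the one measured step that touches the same chain is the move from compound 1 to compound 3, where an acyclic ether group was exchanged for a ring-bearing one and the number moved by a 1.5-fold lower number from compound 1 to compound 3 (0.17 log units; within the scatter), staying within the scatter. Compound 2 also carries a ring-bearing group on this chain and gives a lower number than compound 1, which leaves room for a downward move, but nothing measured isolates the change to a carbon-only ring.

For compound 4 the expected step is therefore small, a 1.6-fold lower number from compound 1 to compound 4 (0.21 log units; within the scatter), tending downward but not clearly beyond the scatter. The estimate for compound 4 is 150 nM, with a range from 50 nM to 450 nM.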

Compound 4, inhibition constant: 124 nM
Compound 4: middle estimate off by 1.2-fold (0.08 log units), on the high side, within the range that was stated.
By their numbers in this assay, from the lowest: compound 2; then compounds 4, 3 and 1 (each within the scatter of the next).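

In this assay, cyclohexyl in place of propoxy gives a 1.9-fold lower number from compound 1 to compound 4 (0.29 log units; within the scatter), so this chain carbon, two bonds along the chain from an amine nitrogen, accepts a six-membered non-aromatic ring of carbon only without a change beyond the scatter. The earlier step, a 1.5-fold lower number from compound 1 to compound 3 (0.17 log units; within the scatter), kept an oxygen in the incoming group, whereas this one shows that a group without oxygen also leaves the number within the scatter of compound 1. Nothing at hand explains this outcome.

As far as these compounds go, whether a phenyl ring, a piperidine or a carboxylic acid at this place would move the number beyond the scatter remains open. Also open, from the compounds shown here alone, is how a longer chain between the amine nitrogen and the cyclohexyl would read in this assay.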